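The source may report more compounds than this note shows. Statements on the series, on what has been measured and on what is new or still open speak of the compounds shown alone.

Measured so far:
- compound 1 `NC1=NC2(CCSCC2)N(OCCCOc2ccc(Cl)c(Cl)c2)C(N)=N1`: 70 nM
- compound 2 `NC1=NC2(CCSCC2)N(OCCCOc2ccc(Br)cc2)C(N)=N1`: 1400 nM

In a functional assay on HepG2 cells (Homo sapiens) for antiproliferative activity, read by MTT assay, with a stated time of 72 h (on this read-out higher numbers stand for weaker inhibition and lower numbers for stronger inhibition), compound 2 gives 1400 nM and so stands at the highest number of the two measured here; its nearest neighbour is compound 1, which in this assay gives 70 nM. Among the compounds with values here, the one measured step, a 20-fold higher number from compound 1 to compound 2 (1.30 log units; beyond the scatter), shows that the exchange of the 3,4-dichlorophenyl for a 4-bromophenyl on an oxygen on a saturated carbon carried a large penalty.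

Compound 3 `NC1=NC2(CCSCC2)N(OCCCOc2cc(Cl)c(Cl)cc2Cl)C(N)=N1` has not yet been measured. It differs from compound 2 in one place: 2,4,5-trichlorophenyl in place of 4-bromophenyl on an oxygen on a saturated carbon. The step from compound 1 to compound 2 bears directly on this, as it runs in the opposite sense, from a single bromine toward a ring carrying several chlorines; a 2,4,5-trichlorophenyl holds the same kind of halogen pattern as compound 1 with one chlorine more. A large drop in the number from compound 2 to compound 3 is therefore expected, a 9.3-fold lower number from compound 2 to compound 3 (0.97 log units; beyond the scatter), bringing compound 3 close to compound 1. In this assay compound 3 is estimated at 150 nM, with a range from 35 nM to 700 nM.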

Compound 3, half-maximal inhibitory concentration: > 100000 nM
Compound 3: a limit, no number; the forecaster's own chance of this, stated with the estimate: 3%; middle value at least 660-fold (2.82 log units) away from the limit.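

In this assay compound 3 gives no number, only a limit of the assay: the limit of > 100000 nM in this assay, at which 1 of the 3 values shown sits.

Even so, the steps can be read, and they show that this position is far less forgiving than the earlier pair suggested: with a chloro in place of hydrogen on an aromatic carbon, the result is an at least 1400-fold higher number from compound 1 to compound 3 (3.15 log units; beyond the scatter), so a single added chloro separates the most favourable ring shown from one with no measurable number. The exchange of 4-bromophenyl for 2,4,5-trichlorophenyl gives an at least 71-fold higher number from compound 2 to compound 3 (1.85 log units; beyond the scatter), which means that the change of ring seen earlier cannot be read as a simple gain from more chlorine: compound 1 fits such a trend, and compound 3 goes against it.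

The compounds shown leave open whether the loss follows from the added chloro as such or from the place it takes on the ring. They also leave open whether a fluoro or a methoxy in that place, or a longer chain on the oxygen, would bring a 2,4,5-substituted phenyl back to a measurable number.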